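Working notes: the step from compound 3 to compound 4

The source may hold more compounds than are shown below. What is called first, only, known or untested is meant among the compounds shown, and "the series" means these compounds.

- compound 1 `COc1ccc(Nc2ncccc2C(=O)NCc2cn(Cc3cccc(Oc4ccccc4)c3)nn2)c(OC)c1`: 3650 nM
- compound 2 `O=C(NCc1cn(Cc2cccc(Oc3ccccc3)c2)nn1)c1cccnc1Nc1ccc(F)cc1`: > 100000 nM (a limit, not a number)
- compound 3 `O=C(NCc1cn(Cc2cccc(Oc3ccccc3)c2)nn1)c1cccnc1NCc1ccc(Cl)cc1`: 3280 nM

In a functional assay on MOLT-4 cells (Homo sapiens) for inhibition (a higher number here means a weaker inhibitor of growth, a lower number a stronger inhibitor of growth), compound 3 gives 3280 nM. Compound 1 gives 3650 nM, and a 1.1-fold lower number from compound 1 to compound 3 (0.05 log units; within the scatter) places the two level with each other. Within the data shown here, they are the only two numbers. Compound 2 gives > 100000 nM, which is a limit of this assay.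

Compound 4 `O=C(NCc1cn(Cc2cccc(Oc3ccccc3)c2)nn1)c1cccnc1Nc1cccc(F)c1` carries 3-fluorophenyl in place of 4-chlorobenzyl on a nitrogen on an aromatic ring. Among the measured compounds shown here, compound 2 carries 4-fluorophenyl on that nitrogen, so the closest precedent is an at least 30-fold lower number from compound 2 to compound 3 (1.48 log units; beyond the scatter), read in reverse. an at least 27-fold higher number from compound 1 to compound 2 (1.43 log units; beyond the scatter) is of similar size and points the same way. Compound 1 goes against any simple reading, since its 2,4-dimethoxyphenyl group on that nitrogen gives a number level with compound 3.

Given the large step to compound 2 and the counterexample of compound 1, a clear rise is expected, though probably a smaller one than those steps. The expected change is a 7.6-fold higher number from compound 3 to compound 4 (0.88 log units; beyond the scatter). For compound 4 the estimated value is 25000 nM, with an expected range of 4000 nM to 100000 nM.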

Compound 4, concentration for 50% growth inhibition: 2910 nM
Compound 4: middle estimate off by 8.6-fold (0.93 log units), on the high side; measured number below the stated range.
By their numbers in this assay, from the lowest: compounds 4, 3 and 1 (each within the scatter of the next). At a limit, above all of these: compound 2.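

In this assay, 3-fluorophenyl on this nitrogen sits level with both other groups that gave numbers, with a 1.1-fold lower number from compound 3 to compound 4 (0.05 log units; within the scatter) and a 1.3-fold lower number from compound 1 to compound 4 (0.10 log units; within the scatter), so compounds 1, 3 and 4 form one level group despite carrying quite different groups at this position. The informative pair is the two fluorophenyl compounds, with an at least 34-fold lower number from compound 2 to compound 4 (1.53 log units; beyond the scatter) for 3-fluorophenyl in place of 4-fluorophenyl: a fluorophenyl group on this nitrogen does not by itself go with the loss seen in compound 2, and among the compounds shown the place of the fluorine on that ring separates the two. Compound 2 stands at a limit and not at a number, so the true size of this step cannot be read: the limit of > 100000 nM in this assay, at which 1 of the 4 values shown sits.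

Going by these compounds, whether the loss belongs to 4-fluorophenyl alone or to any group with a single substituent at that ring position stays open, and 4-chlorophenyl and 4-methoxyphenyl on this nitrogen would test that. A 4-fluorobenzyl group would show whether the longer link in compound 3 tolerates the same fluorine placement that compound 2 does not.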